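Exchanging the side group on the shared core: compound 3

This account rests on a few compounds, and the source may have more. Where it says the series, first, only, none or still open, it means among the compounds named here.

compound 1 `CCc1ccc(N(CC(C)C)S(=O)(=O)c2ccc3c(c2)C(O)CC(C2CCN(S(C)(=O)=O)CC2)O3)cc1` gives 3.22
compound 2 `CCc1ccc(N(CC(C)C)S(=O)(=O)c2ccc3c(c2)C(O)CC(C2CCN(C(=O)C4CCCC4)CC2)O3)cc1` gives 5.04
compound 3 `CCc1ccc(N(CC(C)C)S(=O)(=O)c2ccc3c(c2)C(O)CC(C(C)C2CCOCC2)O3)cc1` is not yet measured

In a physicochemical assay for lipophilicity, at pH 7.4 (on this read-out lower numbers stand for lower lipophilicity and higher numbers for higher lipophilicity), compound 1 stands lowest of the two measured compounds (3.22). The change to compound 3 is 1-(oxan-4-yl)ethyl in place of 1-(methylsulfonyl)piperidin-4-yl on a saturated ring carbon. Going by the values given here, only one measured step bears on it (a number 1.82 log units higher from compound 1 to compound 2 (beyond the scatter)), a large one beyond the scatter, with cyclopentylcarbonyl in place of methylsulfonyl on an amine nitrogen in a ring. Among the compounds with values here, compound 3 also lacks the methylsulfonyl, but a different group enters, and no measured compound carries 1-(oxan-4-yl)ethyl. Within the data shown here, with that single step as the only guide, an upward step of moderate size, smaller than the measured one, is expected in this assay (a number 1.08 log units higher from compound 1 to compound 3 (beyond the scatter)). Compound 3 is estimated at 4.3 (range 3.7 to 4.9).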

Compound 3, distribution coefficient: 5.04
Estimate against measurement, compound 3: 0.74 log units below; the whole stated range lies below it.
By their numbers in this assay, from the lowest: compound 1; then compounds 2 and 3 (each within the scatter of the next).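

In this assay, 1-(oxan-4-yl)ethyl in place of 1-(methylsulfonyl)piperidin-4-yl on this saturated ring carbon gives a number 1.82 log units higher from compound 1 to compound 3 (beyond the scatter), so exchanging the whole group here can produce a large step, not only a change on the amine nitrogen of the ring. Compound 2 at 5.04 and compound 3 at 5.04 lie within the scatter of each other, although their groups at this position differ. No available evidence accounts for the size of this step.

The compounds shown do not separate the contribution of the oxane ring from that of the ethyl link, which a directly attached oxan-4-yl group would address. From the compounds shown here alone, how a free amine or a carboxylic acid at this position would read in this assay also remains open.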